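The source may report more compounds than this note shows. Statements on the series, on what has been measured and on what is new or still open speak of the compounds shown alone.

Values measured in a physicochemical assay for solubility, read by spectrophotometry, in phosphate buffer, with a stated time of 18 h, at pH 7.4 (a higher number here means a more soluble compound, a lower number a less soluble compound), are these:

Compound 1 `CCc1ccc(-c2nc3c(c(C)nn3-c3ccccc3)c(-c3ccccc3C)c2C#N)cc1`: 6000 nM
Compound 2 `Cc1nn(-c2ccccc2)c2nc(-c3ccc(C(C)C)cc3)c(C#N)c(-c3ccccc3O)c12`: 9800 nM
Compound 3 `CCCc1ccc(-c2nc3c(c(C)nn3-c3ccccc3)c(-c3ccccc3O)c2C#N)cc1`: 6500 nM

Compound 3 at 6500 nM lies within the scatter of both compound 1 and compound 2, and the three values show no clear order among them. The next compound to be measured is compound 4 `Cc1nn(-c2ccccc2)c2nc(-c3ccc(Cl)cc3)c(C#N)c(-c3ccccc3O)c12` with chloro in place of propyl on an aromatic carbon, para to a large group. Counted out, the difference is chloro in place of propyl on an aromatic carbon and it turns 4-propylphenyl into 4-chlorophenyl.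

Going by the values given here, only one measured step bears on this place, the change of isopropyl to propyl on an aromatic carbon, and its size is a 1.5-fold lower number from compound 2 to compound 3 (0.18 log units; within the scatter) in this assay for that exchange. Among the compounds with values here, that step stays within the scatter, but it swaps one chain for another, and no measured compound carries chloro. It is therefore only weak guidance, and the range must stay wide. The estimated step is a 1.2-fold higher number from compound 3 to compound 4 (0.09 log units; within the scatter) and no shift beyond the scatter is expected in either direction. For compound 4 the estimated value is 8000 nM with 3000 nM to 20000 nM as the expected range.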

Compound 4, solubility: 3800 nM
Compound 4: the middle estimate sits 2.1-fold (0.32 log units) above what was measured; the range from low to high includes it.
By their numbers in this assay, from the lowest: compounds 4, 1, 3 and 2 (each within the scatter of the next, the first and the last beyond it).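

In this assay the position now shows its first step beyond the scatter, though a modest one: chloro in place of isopropyl on the aromatic carbon gives a 2.6-fold lower number from compound 2 to compound 4 (0.41 log units; beyond the scatter). Chloro in place of propyl at the same carbon gives a 1.7-fold lower number from compound 3 to compound 4 (0.23 log units; within the scatter) and stays within the scatter, so the same entering group reads differently depending on which of the two chains it is set against. Until now this position had shown only an exchange of one chain for another, and these steps add a single chlorine atom as a group of a different kind, with 4-chlorophenyl at the low end of the three compounds that differ only here, yet the separation holds against compound 2 alone. No measurement available here accounts for these differences.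

Going by these compounds, with only isopropyl, propyl and chloro compared at this carbon, it remains open how an amine, a carboxylic acid or a methoxy group would read there. On these data alone, it is also open whether chloro would give a step of similar size on the core of compound 1, which differs from compound 4 in more than one place.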